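Isopropyl to Fluorooxetane: What Compound 3 May Give

The source may report more compounds than this note shows. Statements on the series, on what has been measured and on what is new or still open speak of the compounds shown alone.

Measured so far:
Compound 1 `CC(C)c1ccc(CNC(=O)c2ccn(Cc3ccc(F)c(F)c3)n2)cc1` gives 24 nM in an assay on HEK293 cells for inhibition of Voltage-dependent T-type calcium channel subunit alpha-1G (Homo sapiens), read by FLIPR and calcium flux, with a stated time of 3 min; on this read-out lower numbers stand for stronger inhibition and higher numbers for weaker inhibition.
Compound 2 `O=C(NCc1ccc2[nH]ccc2c1)c1ccn(Cc2ccc(F)c(F)c2)n1` gives 70 nM in this assay.

Within the data shown here, compound 1 holds the lower of the two numbers, and its only neighbour is compound 2, reached by a 2.9-fold higher number from compound 1 to compound 2 (0.46 log units; beyond the scatter), a modest weakening that lies beyond the scatter. Compound 3 `O=C(NCc1ccc(C2(F)COC2)cc1)c1ccn(Cc2ccc(F)c(F)c2)n1` keeps the shared core of compound 1 and alters only one end: 3-fluorooxetan-3-yl in place of isopropyl on an aromatic carbon. Among the measured compounds shown here, no measured step copies this exact change. For the measured compounds named here, the single step in hand, a 2.9-fold higher number from compound 1 to compound 2 (0.46 log units; beyond the scatter), also rebuilt the same end of the molecule and weakened inhibition, so a change of that kind at this end has so far not been free. A loss of similar or somewhat larger size is therefore expected for compound 3, a 4.2-fold higher number from compound 1 to compound 3 (0.62 log units; beyond the scatter). Compound 3 is estimated at 100 nM in this assay, with a likely range from 30 nM to 400 nM.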

Compound 3, half-maximal inhibitory concentration: 53 nM
For compound 3 the middle estimate is 1.9-fold (0.28 log units) above the measured one; the range from low to high includes it.
By their numbers in this assay, from the lowest: compound 1; then compounds 3 and 2 (each within the scatter of the next).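

The change to 3-fluorooxetan-3-yl gives a 2.2-fold higher number from compound 1 to compound 3 (0.34 log units; beyond the scatter) in this assay and so costs only a modest amount, even though the entering group is larger than isopropyl and brings a four-membered ring with an oxygen and a fluorine. This position therefore tolerates a non-aromatic ring, although isopropyl still gives the lowest number of the three compounds, and the numbers for compounds 2 and 3 lie within the scatter of each other. Nothing available here explains why this change weakens inhibition.

The compounds shown leave open which part of the new group accounts for the loss: an oxetan-3-yl group without the fluorine, or a 1-fluorocyclobutyl group with carbon in place of the ring oxygen, would separate the two. They also leave open how a methyl group or an amine would fare at this place.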